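Swapping trifluoromethyl for chloro on a diaryl urea

The source may hold more compounds than are shown below. What is called first, only, known or untested is meant among the compounds shown, and "the series" means these compounds.

Compound 1 `COc1cc2cc(Oc3ccc(NC(=O)Nc4cccc(C(F)(F)F)c4)cc3)c(C)nc2cc1OC` and compound 2 `COc1cc2cc(Oc3ccc(NC(=O)Nc4ccc(Cl)c(C(F)(F)F)c4)cc3)c(C)nc2cc1OC` share one core and differ only on the outer aromatic ring. In a functional assay on OVCAR-3 cells (Homo sapiens) for inhibition, read by sulforhodamine B assay, with a stated time of 48 h (on this read-out lower numbers stand for stronger inhibition of growth and higher numbers for weaker inhibition of growth), compound 1 gives 8070 nM, and compound 2 gives 4450 nM. The step of a 1.8-fold lower number from compound 1 to compound 2 (0.26 log units; within the scatter) is too small to count as a real difference, so compound 2 shows the lower of the two numbers without standing apart from compound 1. Compound 3 `COc1cc2cc(Oc3ccc(NC(=O)Nc4ccc(Cl)c(Cl)c4)cc3)c(C)nc2cc1OC` is the next step from compound 2: chloro in place of trifluoromethyl on an aromatic carbon. Among the measured compounds shown here, no measured pair exchanges these two groups, and the single measured step, a 1.8-fold lower number from compound 1 to compound 2 (0.26 log units; within the scatter), concerns a different change, so it offers no direct guide. With nothing pointing one way, the expected step is a 1.1-fold higher number from compound 2 to compound 3 (0.05 log units; within the scatter) in this assay, that is, no change beyond the scatter. Compound 3 is therefore estimated at 5000 nM, with a likely range from 2000 nM to 12500 nM.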

Compound 3, concentration for total growth inhibition: 6190 nM
The estimate for compound 3 lay 1.2-fold (0.09 log units) below the measured number; the range from low to high includes it.
By their numbers in this assay, from the lowest: compounds 2, 3 and 1 (each within the scatter of the next).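

In this assay, chloro can take the place of trifluoromethyl at this position on the outer ring with no change that stands out from the scatter: the step is a 1.4-fold higher number from compound 2 to compound 3 (0.14 log units; within the scatter). Comparing the 3,4-dichlorophenyl group with the 3-(trifluoromethyl)phenyl group gives the same picture, with a 1.3-fold lower number from compound 1 to compound 3 (0.12 log units; within the scatter), so all three outer rings remain within the scatter of one another. No evidence is available that bears on this result.

Going by these compounds, what remains open is whether any group at this position can move the number beyond the scatter, for example a methoxy group, a nitrile or an amine. It is also unclear whether chloro and trifluoromethyl would remain this close on a different core.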